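From a Four-Membered to a Six-Membered Ring

The source may report more compounds than this note shows. Statements on the series, on what has been measured and on what is new or still open speak of the compounds shown alone.

Among the measured compounds shown here, compound 2 `FC(F)(F)c1cc(NCC2CNC2)c2cn[nH]c2c1` gives 5% in an assay for inhibition of Tryptophan 2,3-dioxygenase (Homo sapiens), with stated times of 10 min and 60 min, tested at 10 uM (a higher number here means a stronger effect of the compound at the concentration tested, a lower number a weaker effect), the lowest of the two numbers measured so far; its nearest neighbour, compound 1 `FC(F)(F)c1cc(NC[C@H]2CCCN2)c2cn[nH]c2c1`, gives 55% in this assay. Compound 3 `FC(F)(F)c1cc(NC[C@@H]2CCCCN2)c2cn[nH]c2c1` has not yet been measured. It differs from compound 2 in one place: piperidin-2-yl in place of azetidin-3-yl on a saturated chain carbon bound to a nitrogen on an aromatic ring. For the measured compounds named here, the only measured step that bears on this change is a number 50 percentage points lower from compound 1 to compound 2 (beyond the scatter), a large loss when pyrrolidin-2-yl was exchanged for azetidin-3-yl at the same place. The present change runs the other way, from azetidin-3-yl to piperidin-2-yl, so a gain in this assay is expected, of a size comparable to that step, though a single step leaves the size uncertain. Compound 3 is therefore expected to give about 40%, within 10% to 70%. That expectation amounts to a number 35 percentage points higher from compound 2 to compound 3 (beyond the scatter).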

Compound 3, a percentage reported as inhibition, at one concentration (the size of the read-out at that concentration, not a potency): 64%
The estimate for compound 3 lay 24 percentage points below the measured number; the range from low to high includes it.
By their numbers in this assay, from the lowest: compound 2; then compounds 1 and 3 (each within the scatter of the next).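

In this assay, the exchange of azetidin-3-yl for piperidin-2-yl gives a number 59 percentage points higher from compound 2 to compound 3 (beyond the scatter), so the low number of compound 2 is not shared by the larger of the two rings on this saturated chain carbon. Exchanging pyrrolidin-2-yl for piperidin-2-yl gives a number 9 percentage points higher from compound 1 to compound 3 (within the scatter), which shows that these two groups cannot be told apart at this position in this assay, while both stand well clear of azetidin-3-yl. No measurement at hand explains these differences.

Azetidin-3-yl differs from the other two groups in both ring size and point of attachment, so the compounds shown cannot separate these two changes; azetidin-2-yl or piperidin-3-yl would bear on that. From the compounds shown here alone, the effect of the opposite stereocentre in the piperidin-2-yl group also remains open.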